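Swapping one aromatic group on compound 2

The source may hold more compounds than are shown below. What is called first, only, known or untested is meant among the compounds shown, and "the series" means these compounds.

Measured so far in a functional assay on SK-OV-3 cells (Homo sapiens) for antiproliferative activity, read by MTT assay, with a stated time of 72 h; a higher number here means a weaker inhibitor, a lower number a stronger inhibitor:
Compound 1 `CC(=O)c1ccc(-c2cccc(NC(=O)CCc3ccc4c(c3)COB4O)c2)cc1`: 79000 nM
Compound 2 `COc1cccc(-c2cccc(NC(=O)CCc3cccc4c3COB4O)c2)c1`: 78000 nM

In this assay compound 2 stands level with compound 1. The two numbers lie within the usual scatter of repeated measurements, so neither can be ranked above the other. Compound 3 `CC(=O)c1ccc(-c2cccc(NC(=O)CCc3cccc4c3COB4O)c2)cc1` has not yet been measured. It differs from compound 2 by carrying 4-acetylphenyl in place of 3-methoxyphenyl on an aromatic carbon. Among the measured compounds shown here, no measured pair isolates this swap. Compound 1 carries the same 4-acetylphenyl on a core that is not identical and gives 79000 nM, so no change beyond the scatter is expected in this assay. The expected 1.0-fold lower number from compound 2 to compound 3 (0.02 log units; within the scatter) is only an estimate. For compound 3 the estimated value is 75000 nM, with an expected range of 38000 nM to 150000 nM.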

Compound 3, half-maximal inhibitory concentration: 57000 nM
Beside the measured number, compound 3's estimate is 1.3-fold (0.12 log units) above it, within the range that was stated.
By their numbers in this assay, from the lowest: compounds 3, 2 and 1 (each within the scatter of the next).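

In this assay, the swap at this aromatic carbon can now be read directly on one core: 4-acetylphenyl in place of 3-methoxyphenyl gives a 1.4-fold lower number from compound 2 to compound 3 (0.14 log units; within the scatter) and so does not separate the two groups. Compound 1 and compound 3 share the 4-acetylphenyl and differ in one place only, on the saturated chain carbon, and the result is a 1.4-fold lower number from compound 1 to compound 3 (0.14 log units; within the scatter) so this difference does not separate them either. No measurement is available that would account for these numbers.

Among the compounds shown here, only two aryl groups have been compared at this position, so it stays open whether a phenyl ring carrying an amine or a carboxylic acid would give a number beyond the scatter. From the compounds shown here alone, what a longer chain in place of the present saturated chain would do is also open.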